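A few compounds are considered here, and "the series" means these few. Any claim that something is new, unique, unknown or untested is made for them only; others in the source may bear on it.

Going by the values given here, in a functional assay for inhibition, with Homo sapiens as the target (on this read-out lower numbers stand for stronger inhibition and higher numbers for weaker inhibition), compound 2 `CC(C)(C)c1ccc(Nc2nccc(-c3cccnc3)n2)cc1` gives 600 nM, the lowest of the two numbers so far; the nearest is compound 1 `CC(=O)Nc1ccc(Nc2nccc(-c3cccnc3)n2)cc1`, which in this assay gives 3600 nM. Among the compounds with values here, the single step between them, a 6.0-fold lower number from compound 1 to compound 2 (0.78 log units; beyond the scatter), is the only guide to the position where compound 3 `c1cncc(-c2ccnc(Nc3ccc(-n4ccnc4)cc3)n2)c1` differs from compound 2: 1H-imidazol-1-yl in place of tert-butyl on an aromatic carbon. That step ran toward a lower number when tert-butyl took the place of acetamido, and the change to compound 3 removes that same tert-butyl again, putting in its place a group with two hydrogen-bond acceptors. Within the data shown here, with no other step to draw on, the step of a 3.0-fold higher number from compound 2 to compound 3 (0.48 log units; beyond the scatter) is expected to run back toward a higher number, smaller than the earlier step yet beyond the scatter. Compound 3 is estimated at 1800 nM, with a range from 600 nM to 6000 nM.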

Compound 3, half-maximal inhibitory concentration: 1300 nM
Estimate against measurement, compound 3: 1.4-fold (0.14 log units) above, and the stated range covers the measured number.
By their numbers in this assay, from the lowest: compound 2; then compound 3; then compound 1.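

In this assay, the change from tert-butyl to 1H-imidazol-1-yl gives a 2.2-fold higher number from compound 2 to compound 3 (0.34 log units; beyond the scatter), while the change from acetamido to the same group gives a 2.8-fold lower number from compound 1 to compound 3 (0.44 log units; beyond the scatter). This places the 1H-imidazol-1-yl group between the two earlier groups at this position: a ring with hydrogen-bond acceptors does not fully bring back the weaker inhibition of compound 1, and tert-butyl, which has no such acceptors, remains the best of the three. Nothing available explains this order.

From the compounds shown here alone, the three compounds do not separate the contribution of the ring from that of its nitrogen atoms, so what sets the place of compound 3 remains open. Going by these compounds, how a morpholine, a carboxylic acid or a cyclohexyl group would compare at this position also remains open.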